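The compounds below may be only part of what the source reports. "The series", "measured", "known", "first", "only" and "open" are said of these compounds alone.

Series notes, shared core. In a functional assay on BEL-7404 cells (Homo sapiens) for cytotoxicity, read by MTT assay, with a stated time of 48 h (a lower number here means a stronger inhibitor, a higher number a weaker inhibitor), compound 1 `CCCCCCCCCC[C@H](O)COCCOC[C@@H](O)CCCCCCCCCCCCC1=C[C@H](C)NC1=O` gives 2200 nM. Compound 2 `CCCCCCCCCC[C@H](O)COCCOC[C@@H](O)CCCCCCCCCCCCC1=C[C@H](C)N(C)C1=O` gives 234 nM in this assay, and compound 3 `CCCCCCCCCC[C@H](O)COCCOC[C@@H](O)CCCCCCCCCCCCC1=CC(C)(C)N(C)C1=O` gives 845 nM. Compound 2 therefore stands lowest of the three numbers: the step of a 9.4-fold lower number from compound 1 to compound 2 (0.97 log units; beyond the scatter) is the largest shown, while a 3.6-fold higher number from compound 2 to compound 3 (0.56 log units; beyond the scatter) and a 2.6-fold lower number from compound 1 to compound 3 (0.42 log units; beyond the scatter) are smaller and keep compound 3 between the other two.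

Compound 4 `CCCCCCCCCC[C@H](O)COCCOC[C@@H](O)CCCCCCCCCCCCC1=C[C@H](C)N(CCCNC(=O)C(F)(F)F)C1=O` is not yet measured. It differs from compound 2 by 2-(((trifluoromethyl)carbonyl)amino)ethyl in place of hydrogen on a saturated chain carbon bound to an amide-type nitrogen in a ring; cut one bond further out, the change reads methyl to 3-(((trifluoromethyl)carbonyl)amino)propyl. Within the data shown here, no measured step puts a larger group on this amide-type nitrogen. Among the measured compounds shown here, the steps that bear on it are a 9.4-fold lower number from compound 1 to compound 2 (0.97 log units; beyond the scatter), showing that this position is sensitive, and a 3.6-fold higher number from compound 2 to compound 3 (0.56 log units; beyond the scatter), showing that adding carbon near it can raise the number again. A modest step in this assay, more likely upward than downward, is expected: a 1.9-fold higher number from compound 2 to compound 4 (0.28 log units; within the scatter). Compound 4 is estimated at 450 nM, within 120 nM to 1700 nM.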

Compound 4, half-maximal inhibitory concentration: 1350 nM
The estimate for compound 4 lay 3.0-fold (0.48 log units) below the measured number; the measured number falls inside the stated range.
By their numbers in this assay, from the lowest: compound 2; then compounds 3, 4 and 1 (each within the scatter of the next, the first and the last beyond it).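

Notes on the amide-type nitrogen in a ring: in this assay, this position now carries a group larger than methyl, and the gain seen with methyl does not persist with 3-(((trifluoromethyl)carbonyl)amino)propyl (a 5.8-fold higher number from compound 2 to compound 4 (0.76 log units; beyond the scatter)). Measured against the amide hydrogen, this longer substituent gives no separable change (a 1.6-fold lower number from compound 1 to compound 4 (0.21 log units; within the scatter)), so the step from hydrogen to a substituent on this nitrogen does not lower the number in every case shown. Nothing at hand accounts for the difference between methyl and this substituent.

The compounds shown do not separate the contribution of the propyl chain from that of its (trifluoromethyl)carbonyl amino end. A plain propyl group or a 3-aminopropyl group on the same nitrogen would make that distinction, and an ethyl group would show how the number behaves with a chain just longer than methyl.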